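The source may report more compounds than this note shows. Statements on the series, on what has been measured and on what is new or still open speak of the compounds shown alone.

Compound 1 `O=c1c(C2=CS(=O)(=O)c3cc(O)ccc3N2)c(O)c2cc(F)ccc2n1Cc1ccc(F)cc1` — in an ADME assay on 2209-23 cells (Homo sapiens) for cytotoxicity, read by WST assay (a lower number here means that less compound is tolerated, a higher number that more compound is tolerated), compound 1 gives > 50000 nM, which is a limit of the assay rather than a number.
Compound 2 `Nc1ccc2c(c1)S(=O)(=O)C=C(c1c(O)c3cc(F)ccc3n(Cc3ccc(F)cc3)c1=O)N2` — in this assay compound 2 gives > 50000 nM, again a limit of the assay and not a number.

Within the data shown here, compound 2 therefore stands at the limit in this assay, and the one further value shown is also a limit. Among the measured compounds shown here, the only measured step, a step that the two limits leave unreadable from compound 1 to compound 2, is not readable in size, since both of its ends sit at the limit; this is the whole evidence in hand, (the limit of > 50000 nM in this assay, at which 2 of the 2 values shown sit).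

Compound 3 `NC(=O)COc1ccc2c(c1)S(=O)(=O)C=C(c1c(O)c3cc(F)ccc3n(Cc3ccc(F)cc3)c1=O)N2` is the compound not yet measured. It differs from compound 2 in one place: carbamoylmethoxy in place of amino on an aromatic carbon. For the measured compounds named here, no measured step bears directly on this exchange, and the one step that is known could not be read. The expectation for compound 3 in this assay is therefore no step beyond the scatter, with compound 3 expected to remain at or beyond the limit where compound 2 stands, a step that the limit leaves unreadable from compound 2 to compound 3. Compound 3 is thus estimated at 80000 nM, within 30000 nM to 300000 nM.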

Compound 3, half-maximal cytotoxic concentration: > 50000 nM
Compound 3 was reported as a limit (the forecaster's own chance of this, stated with the estimate: 85%); the middle value lies beyond the limit too.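

In this assay compound 3 gives > 50000 nM, which is a limit of the assay and not a number. Neither new step, from compound 2 to compound 3 or from compound 1 to compound 3, can be read. The compounds shown leave open how far compound 1, compound 2 and compound 3 differ in cytotoxicity, if they differ at all: the limit of > 50000 nM in this assay, at which 3 of the 3 values shown sit.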